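The source may hold more compounds than are shown below. What is called first, only, known or untested is meant among the compounds shown, and "the series" means these compounds.

Compound 1 `O=C(CCCSc1nc2cc(Cl)ccc2o1)N1CCCC1` gives 125 mL/min/g; compound 2 `O=C(CCSc1nc2cc(Cl)ccc2o1)N1CCC1` gives 17.9 mL/min/g; compound 3 `Clc1ccc2oc(SCCCN3CCCC3)nc2c1` gives 10.4 mL/min/g in an ADME assay on microsomes from liver (Mus musculus) for metabolic stability, read by LC-MS, using NADPH, with a stated time of 45 min, tested at 0.5 uM; a lower number here means slower removal, a higher number faster removal of the compound.

Compound 3 has the lowest number of the three. The step from the amide of compound 1 to the amine of compound 3 was large, a 12-fold lower number from compound 1 to compound 3 (1.08 log units; beyond the scatter), while the related step of a 1.7-fold lower number from compound 2 to compound 3 (0.24 log units; within the scatter) stayed within the scatter. Compound 4 `O=C1CCCN1CCCSc1nc2cc(Cl)ccc2o1` differs from compound 3 by 2-oxopyrrolidin-1-yl in place of pyrrolidin-1-yl on a saturated chain carbon, three bonds along the chain from a sulfur. This reintroduces a carbonyl on the ring nitrogen at the place where compound 1 carried its carbonyl, so the step of a 12-fold lower number from compound 1 to compound 3 (1.08 log units; beyond the scatter) bears most, and a move back toward a higher number is expected, tempered by compound 2. For compound 4 the expected value is 40 mL/min/g, between 12 mL/min/g and 130 mL/min/g, a step of a 3.8-fold higher number from compound 3 to compound 4 (0.59 log units; beyond the scatter).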

Compound 4, intrinsic clearance in a liver preparation (reported as CLH), per the amount of preparation that the assay uses: 51 mL/min/g
Compound 4: middle estimate off by 1.3-fold (0.11 log units), on the low side, and the stated range covers the measured number.
By their numbers in this assay, from the lowest: compounds 3 and 2 (each within the scatter of the next); then compound 4; then compound 1.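

At this place, three bonds along the chain from a sulfur, 2-oxopyrrolidin-1-yl behaves like neither neighbouring group in this assay: replacing pyrrolidin-1-yl gives a 4.9-fold higher number from compound 3 to compound 4 (0.69 log units; beyond the scatter), while replacing (pyrrolidin-1-yl)carbonyl gives a 2.5-fold lower number from compound 1 to compound 4 (0.39 log units; beyond the scatter). The number at this position therefore does not simply divide into two levels, one with a carbonyl and one without. Nothing shown gives a cause for these steps.

On these data alone, whether a piperidine or a morpholine at this place would fall in the same range remains open. So does the effect of a longer chain carrying 2-oxopyrrolidin-1-yl.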